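A few compounds are considered here, and "the series" means these few. Any claim that something is new, unique, unknown or untested is made for them only; others in the source may bear on it.

Of the compounds shown here, three sharing one core have been measured, and a fourth awaits its number. Compound 1 `CC(C)(C)NC(=O)c1c(N)sc(-c2ccc(Cl)cc2)c1-c1ccc(Cl)cc1` carries a tert-butyl group on the amide-type nitrogen; in a functional assay on A549 cells (Homo sapiens) for inhibition, read by sulforhodamine B assay, with a stated time of 72 h (a higher number here means a weaker inhibitor, a lower number a stronger inhibitor), compound 1 gives 8850 nM. Compound 2 `Nc1sc(-c2ccc(Cl)cc2)c(-c2ccc(Cl)cc2)c1C(=O)NC1CC1`, with a cyclopropyl group in that place, gives 1950 nM, and compound 3 `Nc1sc(-c2ccc(Cl)cc2)c(-c2ccc(Cl)cc2)c1C(=O)N1CCCCC1=O`, with a 2-oxopiperidin-1-yl group on the carbonyl carbon, gives 1820 nM. Among these three numbers, compound 1 stands highest, so it is the weakest inhibitor shown: the step of a 4.5-fold lower number from compound 1 to compound 2 (0.66 log units; beyond the scatter) and the step of a 4.9-fold lower number from compound 1 to compound 3 (0.69 log units; beyond the scatter) both lie beyond the scatter, while a 1.1-fold lower number from compound 2 to compound 3 (0.03 log units; within the scatter) does not.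

Compound 4 `Nc1sc(-c2ccc(Cl)cc2)c(-c2ccc(Cl)cc2)c1C(=O)NC1CCC1` differs from compound 1 in one place: cyclobutyl in place of tert-butyl on an amide-type nitrogen. The step that bears most directly on this change is a 4.5-fold lower number from compound 1 to compound 2 (0.66 log units; beyond the scatter), where a small carbon ring likewise replaced tert-butyl on the same nitrogen; the step of a 4.9-fold lower number from compound 1 to compound 3 (0.69 log units; beyond the scatter) points the same way. A change of similar size and direction is therefore expected here, in this assay, namely a 3.5-fold lower number from compound 1 to compound 4 (0.55 log units; beyond the scatter). Compound 4 is expected to give about 2500 nM, with a range from 1200 nM to 5500 nM.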

Compound 4, half-maximal inhibitory concentration: 12500 nM
The estimate for compound 4 lay 5.0-fold (0.70 log units) below the measured number; the measured number lies above the stated range.
By their numbers in this assay, from the lowest: compounds 3 and 2 (each within the scatter of the next); then compounds 1 and 4 (each within the scatter of the next).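

Cyclobutyl on the amide-type nitrogen does not repeat what cyclopropyl did there: in this assay the change from tert-butyl gives a 1.4-fold higher number from compound 1 to compound 4 (0.15 log units; within the scatter) and leaves compound 4 indistinguishable from compound 1. Having a small carbon ring at this place is thus not enough, as swapping one ring for the other gives a 6.4-fold higher number from compound 2 to compound 4 (0.81 log units; beyond the scatter) and the change from the 2-oxopiperidin-1-yl group to cyclobutylamino gives a 6.9-fold higher number from compound 3 to compound 4 (0.84 log units; beyond the scatter) on the same carbonyl carbon. Nothing available here explains why these two rings part so clearly.

The compounds shown leave open whether this advantage belongs to cyclopropyl alone. A methyl group, an ethyl chain or a cyclopentyl ring on the same nitrogen could fall with compound 2 or with compounds 1 and 4.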